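Oxolanyl in Place of Hydrogen: Expected Effect on Cytotoxicity

The source may report more compounds than this note shows. Statements on the series, on what has been measured and on what is new or still open speak of the compounds shown alone.

Compound 1, `CN1C(=S)[C@@H](NC(=O)c2n[nH]c(Cc3ccccc3)n2)COc2ccccc21`, reaches only a limit in a toxicity assay on HT-29 cells (Homo sapiens) for cytotoxicity (on this read-out lower numbers stand for higher toxicity in this test and higher numbers for lower toxicity in this test), namely > 50000 nM.
Compound 2, `CCCCn1nc(C(=O)N[C@H]2COc3ccccc3N(C)C2=S)nc1Cc1ccccc1`, also stops at a limit in this assay, namely > 100000 nM.
Compound 3, `CN1C(=S)[C@@H](NC(=O)c2nc(Cc3ccccc3)n(CCCCC#N)n2)COc2ccccc21`, likewise gives a limit in this assay, namely > 100000 nM.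

Compound 1 therefore stands at a limit of this assay and not at a number. Its two companions stand at limits as well, so none of the three can be ranked against the others. The unmeasured compound 4 is `CN1C(=S)[C@@H](NC(=O)c2nc(Cc3ccccc3)n(C3CCOC3)n2)COc2ccccc21`. The change from compound 1 to compound 4 is oxolan-3-yl in place of hydrogen on an aromatic nitrogen.

Among the measured compounds shown here, three measured steps touch the same aromatic nitrogen: a step that the two limits leave unreadable from compound 1 to compound 2, a step that the two limits leave unreadable from compound 1 to compound 3 and a step that the two limits leave unreadable from compound 2 to compound 3. Their sizes stay hidden because the limit of > 100000 nM in this assay, at which 2 of the 3 values shown sit, and the limit of > 50000 nM in this assay, at which 1 of the 3 values shown sits, bound every value involved. What they do show is that neither a butyl nor a 4-cyanobutyl group on this nitrogen brought the cytotoxicity into the measurable range.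

For the oxolan-3-yl group the same outcome is expected: no step beyond the scatter, with compound 4 estimated to remain at a limit, so that a step that the limit leaves unreadable from compound 1 to compound 4 is expected to be unreadable. The estimate for compound 4 in this assay is 100000 nM, within 50000 nM to 200000 nM.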

Compound 4, half-maximal cytotoxic concentration: > 100000 nM
Compound 4: a limit, no number (the forecaster's own chance of this, stated with the estimate: 85%); the middle value sits exactly at the limit.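

In this assay, among the compounds shown here, compound 4 also stops at a limit, > 100000 nM, so no step to compound 4 from compound 1, compound 2 or compound 3 can be read. The compounds shown leave open where the cytotoxicity of any of the four actually lies, and whether any group on this aromatic nitrogen would bring it into the measurable range.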